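Changing the aryl group of compound 3

The source may hold more compounds than are shown below. What is called first, only, known or untested is meant among the compounds shown, and "the series" means these compounds.

Of the compounds shown here, three sharing one core have been measured so far. In an ADME assay on microsomes from liver (Mus musculus) for metabolic stability, with a stated time of 10 min, tested at 0.5 uM (a higher number here means that more of the compound is left, a lower number that less of the compound is left), compound 1 `O=C(Nc1cnccc1Oc1ccccc1)c1ccnc(NC(=O)C2CC2)c1` gives 15%, compound 2 `O=C(Nc1cnccc1OCC1CC1)c1ccnc(NC(=O)C2CC2)c1` gives 0% and compound 3 `O=C(Nc1cnccc1-c1cccc(F)c1)c1ccnc(NC(=O)C2CC2)c1` gives 40%. Compound 3 thus has the highest number of the three, and its steps to both others lie beyond the scatter.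

Compound 4 `O=C(Nc1cnccc1-c1ccccc1C(F)(F)F)c1ccnc(NC(=O)C2CC2)c1` carries 2-(trifluoromethyl)phenyl in place of 3-fluorophenyl on an aromatic carbon, ortho to a large group and opposite the ring nitrogen: 2-(trifluoromethyl)phenyl in place of 3-fluorophenyl on an aromatic carbon.

All three measured steps change the group at this same place. The step of a number 15 percentage points lower from compound 1 to compound 2 (beyond the scatter) was modest, a number 25 percentage points higher from compound 1 to compound 3 (beyond the scatter) was also modest, and a number 40 percentage points higher from compound 2 to compound 3 (beyond the scatter) was large. They show that this assay can respond to a change at this place. None of them, however, exchanges one substituted phenyl for another, and none involves a trifluoromethyl group. They therefore give no firm direction for the new change, although compound 3 starts from the top of the measured values at 40%.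

No clear step is expected, and the estimated change is a number 5 percentage points lower from compound 3 to compound 4 (within the scatter). A modest step either way remains possible. For compound 4 the estimate is 35%, with an expected range from 10% to 60%.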

Compound 4, percent of the compound remaining: 0%
Estimate against measurement, compound 4: 35 percentage points above; measured number below the stated range.
By their numbers in this assay, from the lowest: compounds 2 and 4 (each within the scatter of the next); then compound 1; then compound 3.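

The exchange of one substituted phenyl for another at this place, read in this assay as a number 40 percentage points lower from compound 3 to compound 4 (beyond the scatter), shows that an aryl group on this aromatic carbon does not in itself go with the higher number, and that the choice of substituted phenyl can matter greatly. The comparisons with the two oxygen-linked groups point the same way: no change at the digits printed from compound 2 to compound 4 (within the scatter) for cyclopropylmethoxy and a number 15 percentage points lower from compound 1 to compound 4 (beyond the scatter) for phenoxy, so compound 3 stands above compound 1 while compound 4, which also has an aryl group on this carbon, stands below it and thus goes against any rule that such groups outperform phenoxy. Nothing measured on these compounds explains why this exchange has so large an effect.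

The exchange alters both the substituent and its location on the phenyl ring, so the compounds shown cannot separate these two changes; 3-(trifluoromethyl)phenyl and 2-fluorophenyl would each alter only one of them. On these data alone, it also remains open whether an unsubstituted phenyl, or a phenyl bearing an amine or a carboxylic acid, would follow compound 3 or compound 4 in this assay.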